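Series notes: ether replacement on compound 1

The source may report more compounds than this note shows. Statements on the series, on what has been measured and on what is new or still open speak of the compounds shown alone.

Measured so far:
compound 1 `CCS(=O)(=O)Nc1ccc(Oc2ccccc2)c(-c2cn(C)c(=O)c3[nH]ccc23)c1` — 917 mL/min/kg
compound 2 `Cn1cc(-c2cc(S(N)(=O)=O)ccc2Oc2ccccc2)c2cc[nH]c2c1=O` — 517 mL/min/kg
compound 3 `Cn1cc(-c2cc(NS(C)(=O)=O)ccc2OC2CCC(F)(F)CC2)c2cc[nH]c2c1=O` — 717 mL/min/kg

In an ADME assay on microsomes from liver (Mus musculus) for metabolic stability (on this read-out lower numbers stand for slow clearance and higher numbers for fast clearance), compound 1 stands at the top of the three numbers, but its gaps to compound 3 and to compound 2 are both within the scatter, so no order among them can be read. Among the measured compounds shown here, the only single-point step, a 1.8-fold lower number from compound 1 to compound 2 (0.25 log units; within the scatter), touches the sulfonamide, not the ether. Compound 4 `CCS(=O)(=O)Nc1ccc(OCC(C)(C)C)c(-c2cn(C)c(=O)c3[nH]ccc23)c1` carries the change (neopentyl in place of phenyl on an oxygen on an aromatic ring). For the measured compounds named here, no measured step alters the ether alone: compound 3 differs from compound 1 in both ether and sulfonamide, and the two values merely sit within scatter of each other. No step beyond the scatter is therefore expected in this assay. Compound 4 is estimated at 800 mL/min/kg, range 400 mL/min/kg to 1600 mL/min/kg. The expected step is a 1.1-fold lower number from compound 1 to compound 4 (0.06 log units; within the scatter).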

Compound 4, clearance: 1030 mL/min/kg
Compound 4: the middle estimate sits 1.3-fold (0.11 log units) below what was measured; the range from low to high includes it.
By their numbers in this assay, from the lowest: compounds 2, 3, 1 and 4 (each within the scatter of the next).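

Among the compounds shown here, this is the first step that alters the ether alone: in this assay, neopentyl in place of phenyl on an oxygen on an aromatic ring gives a step within the scatter (a 1.1-fold higher number from compound 1 to compound 4 (0.05 log units; within the scatter)). At this position, then, an open chain with no ring reads the same as the aromatic ring in this one pair. No measurement at hand bears on the reason for this result.

Still open, going by these compounds, is whether an amine or a carboxylic acid on this chain would give a step beyond the scatter in this assay. Neopentyloxy is also shown only with the (ethylsulfonyl)amino group, so its reading with sulfamoyl remains unknown.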